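Swapping ethoxy for methyl on compound 2

The compounds below may be only part of what the source reports. "The series", "measured", "known", "first", "only" and "open" are said of these compounds alone.

Compound 1 `O=C1C=C(NCc2ccccc2)C(=O)c2c1nc1n2[C@H]2OC[C@@H](O)[C@H]2OC1`: > 8000 nM (a limit, not a number)
Compound 2 `CCOc1ccc(NC2=CC(=O)c3nc4n(c3C2=O)[C@H]2OC[C@@H](O)[C@H]2OC4)cc1`: 1430 nM

For the measured compounds named here, in a functional assay on MCF7 cells (Homo sapiens) for inhibition, read by sulforhodamine B assay (a higher number here means a weaker inhibitor, a lower number a stronger inhibitor), compound 2 gives 1430 nM, the only true number so far. Compound 1 gives > 8000 nM, which is a limit of the assay. Compound 3 `Cc1ccc(NC2=CC(=O)c3nc4n(c3C2=O)[C@H]2OC[C@@H](O)[C@H]2OC4)cc1` differs from compound 2 in one place, with methyl in place of ethoxy on an aromatic carbon, para to a large group (methyl in place of ethoxy on an aromatic carbon). Going by the values given here, the one measured step is an at least 5.5-fold lower number from compound 1 to compound 2 (0.74 log units; beyond the scatter), and it bears only loosely, since it exchanged the whole group on the amine nitrogen. Among the compounds with values here, no measured step tests ethoxy against methyl, so no step beyond the scatter is expected in this assay. For compound 3 the estimate is 1800 nM, with an expected range from 600 nM to 5500 nM. This estimate means an expected 1.3-fold higher number from compound 2 to compound 3 (0.10 log units; within the scatter).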

Compound 3, half-maximal inhibitory concentration: 1660 nM
Compound 3: the middle estimate sits 1.1-fold (0.04 log units) above what was measured, and the stated range covers the measured number.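

In this assay, exchanging ethoxy for methyl on this aromatic carbon, para to a large group, gives a 1.2-fold higher number from compound 2 to compound 3 (0.06 log units; within the scatter), so the oxygen and the longer chain of ethoxy are not needed to keep the activity seen in this pair. With 4-methylphenyl on the amine nitrogen, the comparison with benzyl gives an at least 4.8-fold lower number from compound 1 to compound 3 (0.68 log units; beyond the scatter), so a second substituted phenyl now stands apart from benzyl. This comparison gives only a minimum size, since compound 1 has a limit and not a number: the limit of > 8000 nM in this assay, at which 1 of the 3 values shown sits.

On these data alone, what remains open is whether a different group at this place, such as an amine, a carboxylic acid or a longer alkoxy chain, would shift the number beyond the scatter. Also open, as far as these compounds go, is how a plain phenyl, with only hydrogen there, would compare with compound 2 and compound 3.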